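Methoxyphenyl Out, Chlorophenyl In: What to Expect

The source may hold more compounds than are shown below. What is called first, only, known or untested is meant among the compounds shown, and "the series" means these compounds.

Three compounds sharing one core were tested in a functional assay on the whole organism (plasma) with Mus musculus as the target, with a stated time of 15 days, at a dose of 30 mg/kg by the oral route; a higher number here means a stronger effect of the compound at the dose given, a lower number a weaker effect. Compound 1 `COc1ccc(/C=C2\SC(=O)N(Cc3ccc(C)cc3)C2=O)c(OC)c1` gives 46.5%, compound 2 `Cc1ccc(CN2C(=O)S/C(=C\c3ccc(N(C)C)cc3)C2=O)cc1` gives 44.1%, and compound 3 `COc1ccc(/C=C2\SC(=O)N(Cc3ccc(C)cc3)C2=O)cc1` gives 58.8%, the highest of the three, with both gaps beyond the scatter. The step of a number 12.3 percentage points higher from compound 1 to compound 3 (beyond the scatter) and the step of a number 14.7 percentage points higher from compound 2 to compound 3 (beyond the scatter) show that changes on this aromatic ring moved the read-out by modest amounts. Compound 4 `Cc1ccc(CN2C(=O)S/C(=C\c3ccccc3Cl)C2=O)cc1` is not yet measured; it differs from compound 3 by 2-chlorophenyl in place of 4-methoxyphenyl on a double-bonded chain carbon bound to a double-bonded ring carbon. Among the measured compounds shown here, no measured step puts a chlorine on this ring, so the direction is open, and a modest change either way is about as likely as none beyond the scatter. Compound 4 is therefore expected to give about 50%, between 35% and 65%, a step of a number 8.8 percentage points lower from compound 3 to compound 4 (within the scatter).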

Compound 4, a percentage reported as activity, at one dose (the size of the read-out at that dose, not a potency): 26%
For compound 4 the middle estimate is 24 percentage points above the measured one; measured number outside the range, below it.
By their numbers in this assay, from the lowest: compound 4; then compounds 2 and 1 (each within the scatter of the next); then compound 3.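

In this assay, replacing 4-methoxyphenyl with 2-chlorophenyl gives a number 32.8 percentage points lower from compound 3 to compound 4 (beyond the scatter), a large step where the earlier changes on this ring were modest, so this group can move the read-out much further than those compounds suggested. The swap removes the methoxy, adds a chlorine and changes the numbered ring position at once, so their separate contributions cannot be told apart. Nothing available explains the drop. Going by these compounds, whether 4-chlorophenyl or plain phenyl here would land nearer compound 3 or compound 4 remains open.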